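Benzophenone ester series: methoxy to chloro on the benzoyl ring

A few compounds are considered here, and "the series" means these few. Any claim that something is new, unique, unknown or untested is made for them only; others in the source may bear on it.

Compound 1 `COc1cccc(C(=O)c2ccc(OC)c(OC(=O)CCC(=O)OC[C@@H]3C=C[C@H](n4cc(C)c(=O)[nH]c4=O)O3)c2)c1` is the stronger of the two compounds measured in a functional assay on SGC-7901 cells (Homo sapiens) for antiproliferative activity, read by MTT assay, with a stated time of 48 h (a higher number here means a weaker inhibitor, a lower number a stronger inhibitor), where compound 1 gives 770 nM. Within the data shown here, the other, compound 2 `COc1ccc(C(=O)c2ccc(F)cc2)cc1OCC(=O)OC[C@@H]1C=C[C@H](n2cc(C)c(=O)[nH]c2=O)O1`, gives 29100 nM, a much higher number, beyond the scatter; the two differ in several places, so no single step connects them. Compound 3 `COc1ccc(C(=O)c2cccc(Cl)c2)cc1OC(=O)CCC(=O)OC[C@@H]1C=C[C@H](n2cc(C)c(=O)[nH]c2=O)O1` is not yet measured; it differs from compound 1 by chloro in place of methoxy on an aromatic carbon. Among the measured compounds shown here, no measured pair shows this change, so a step within the scatter is expected in this assay, in no firm direction, amounting to a 1.3-fold higher number from compound 1 to compound 3 (0.11 log units; within the scatter). Compound 3 is estimated at 1000 nM, within a range of 300 nM to 3500 nM.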

Compound 3, half-maximal inhibitory concentration: 4190 nM
The estimate for compound 3 lay 4.2-fold (0.62 log units) below the measured number; the measured number lies above the stated range.
By their numbers in this assay, from the lowest: compound 1; then compound 3; then compound 2.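

Among these compounds, on the 3-methoxyphenyl ring, chloro does not stand in for methoxy: in this assay the change gives a 5.4-fold higher number from compound 1 to compound 3 (0.74 log units; beyond the scatter) and is the first single-place step. The ring position, meta to a large group, therefore responds to the group it carries, though this rests on one pair and favours methoxy only there. Nothing available speaks to the cause of the step. Open, on these data alone, is how an amine or a hydroxy group would read at this position. Also open, as far as these compounds go, is whether the step holds with a linker other than that of compound 1.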